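This account rests on a few compounds, and the source may have more. Where it says the series, first, only, none or still open, it means among the compounds named here.

Series notes. Of the compounds shown here, three built on one shared core have been measured in an assay on membranes from CHO cells for displacement of a labelled ligand from adenosine receptor A1 (Homo sapiens), read by scintillation counting, with a stated time of 60 min, tested at 1 uM; on this read-out lower numbers stand for less inhibition and higher numbers for more inhibition at the one concentration tested (going by the name of the read-out). Compound 1 `CC1=C(C(=O)CC(C)C)C(c2ccco2)NC(=O)N1` gives 16%. Compound 2 `CC1=C(C(=O)SC(C)C)C(c2ccco2)NC(=O)N1` gives 5%. Compound 3 `CC1=C(C(=O)OC2CCCC2)C(c2ccco2)NC(=O)N1` gives 1%. Compound 3 thus holds the lowest of the three numbers; the step of a number 4 percentage points lower from compound 2 to compound 3 (within the scatter) lies within the scatter, so compounds 2 and 3 cannot be told apart, whereas the step of a number 15 percentage points lower from compound 1 to compound 3 (beyond the scatter) lies beyond it, as does the step of a number 11 percentage points lower from compound 1 to compound 2 (beyond the scatter).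

Compound 4 `CC1=C(C(=O)OC2CCCCC2)C(c2ccco2)NC(=O)N1` differs from compound 3 in one place: cyclohexyl in place of cyclopentyl on an oxygen next to a carbonyl group. Among the compounds with values here, none of the measured steps alters a ring on the oxygen: the two steps starting from compound 1 replace isobutyl by isopropylsulfanyl or cyclopentyloxy on the carbonyl carbon, and the step from isopropylsulfanyl to cyclopentyloxy stays within the scatter. Within the data shown here, no measured step therefore bears directly on the exchange of cyclopentyl for cyclohexyl, and the closest comparisons give no ground to expect a step beyond the scatter in this assay. For compound 4 the expected step is a number 2 percentage points higher from compound 3 to compound 4 (within the scatter). Compound 4 is accordingly estimated at 3%, with a range from 0% to 12%.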

Compound 4, a percentage reported as inhibition, at one concentration (the size of the read-out at that concentration, not a potency): 1%
Estimate against measurement, compound 4: 2 percentage points above; the measured number falls inside the stated range.
By their numbers in this assay, from the lowest: compounds 3, 4 and 2 (each within the scatter of the next); then compound 1.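

In this assay, within the data shown here, the first measured exchange on the oxygen next to the carbonyl group gives no change at the digits printed from compound 3 to compound 4 (within the scatter), so at this position cyclohexyl and cyclopentyl cannot be told apart at the one concentration tested. Cyclohexyloxy on the carbonyl carbon also falls in with the other two non-isobutyl groups: isopropylsulfanyl gives way to it with a number 4 percentage points lower from compound 2 to compound 4 (within the scatter), whereas replacing isobutyl gives a number 15 percentage points lower from compound 1 to compound 4 (beyond the scatter), the same size as the step to cyclopentyloxy, so compound 1 remains the only member set apart by steps beyond the scatter. Nothing available explains why these two rings read alike or why compound 1 stands apart.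

With compound 3 and compound 4 both so low in this assay, the series leaves open whether any ring size on this oxygen matters, since a single concentration cannot separate compounds at this end of the scale. It also leaves open how a straight hexyl chain, a benzyl group or a chain ending in an amine on the same oxygen would read, and whether a ketone side chain longer than isobutyl would raise the number above that of compound 1.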